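Amino chain length on the shared core, growth inhibition

The compounds below may be only part of what the source reports. "The series", "measured", "known", "first", "only" and "open" are said of these compounds alone.

Compound 1 `CCCNc1ncnc2c1cnn2-c1ccccc1` carries a propylamino group on the shared core with hydrogen on the aromatic carbon; in a functional assay on G-361 cells (Homo sapiens) for cytotoxicity, read by sulforhodamine B assay (a lower number here means a stronger inhibitor of growth, a higher number a weaker inhibitor of growth), compound 1 gives > 100000 nM, which is a limit of the assay and not a number. Compound 2 `CCCNc1nc(C)nc2c1cnn2-c1ccccc1` has methyl in place of that hydrogen; in this assay compound 2 gives > 100000 nM, again a limit. Compound 3 `Cc1nc(NC(C)C)c2cnn(-c3ccccc3)c2n1` has isopropyl in place of propyl on the nitrogen on the aromatic ring; in this assay compound 3 gives > 100000 nM, also a limit. Compound 3 thus stands where the other two stand, at the limit of > 100000 nM in this assay, at which 3 of the 3 values shown sit, and no ordering among the three can be read. The step that the two limits leave unreadable from compound 1 to compound 2 and the step that the two limits leave unreadable from compound 2 to compound 3 are accordingly unreadable in size.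

Compound 4 `CCCCNc1nc(C)nc2c1cnn2-c1ccccc1` differs from compound 3 by butyl in place of isopropyl on a nitrogen on an aromatic ring. The step that bears on it most directly, a step that the two limits leave unreadable from compound 2 to compound 3, altered the same nitrogen substituent and left both compounds at the limit, so no size or direction in this assay can be taken from it. The expected step in this assay is a number no higher from compound 3 to compound 4 (the limit leaves the size open), that is none beyond the scatter, with the result most likely again reported as a limit. For compound 4 in this assay the estimate is 100000 nM, with a range from 30000 nM to 300000 nM.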

Compound 4, concentration for total growth inhibition: > 100000 nM
Compound 4 ended at the assay's limit (the forecaster's own chance of this, stated with the estimate: 85%); the middle value lies on the limit itself.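

In this assay compound 4 gives > 100000 nM, a limit of the assay and not a number. No new step can be read for compound 4 against compound 2 or compound 3: the limit of > 100000 nM in this assay, at which 4 of the 4 values shown sit.

The compounds shown leave open how the propylamino, isopropylamino and butylamino groups rank, and whether any change on the shared core brings a readable value in this assay.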